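The source may report more compounds than this note shows. Statements on the series, on what has been measured and on what is new or still open speak of the compounds shown alone.

Measured compounds in a functional assay on PC-3 cells (Homo sapiens) for cytotoxicity, read by MTT assay, with a stated time of 72 h; a lower number here means a stronger inhibitor, a higher number a weaker inhibitor:
compound 1, `COc1ccc(S(=O)(=O)c2nc3ccccc3nc2Nc2cc(OC)cc(OC)c2)cc1`, 6220 nM
compound 2, `COc1ccc(S(=O)(=O)c2nc3ccccc3nc2Nc2ccc(N)cc2)cc1`, 9640 nM
compound 3, `COc1cc(Nc2nc3ccccc3nc2S(=O)(=O)c2ccc(Br)cc2)cc(OC)c1`, 18200 nM

Compound 4, `Nc1ccc(Nc2nc3ccccc3nc2S(=O)(=O)c2ccc(Br)cc2)cc1`, has not yet been measured in this assay.

The cores of compound 1 and compound 3 differ by bromo in place of methoxy on an aromatic carbon; this difference gave a 2.9-fold higher number from compound 1 to compound 3 (0.47 log units; beyond the scatter). Among the three measured compounds, compound 3 gives the highest number, though its gap to compound 2 lies within the scatter, and only its gap to compound 1 lies beyond it.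

Compound 4 stands to compound 3 as compound 2 stands to compound 1. The difference 4-aminophenyl in place of 3,5-dimethoxyphenyl on a nitrogen on an aromatic ring is the same change as 4-aminophenyl in place of 3,5-dimethoxyphenyl on a nitrogen on an aromatic ring, made at the same place, and the descriptions of the place agree word for word, so the change counts as the same one. Where it has been measured it gave a 1.5-fold higher number from compound 1 to compound 2 (0.19 log units; within the scatter), a step within the scatter.

Among the measured compounds shown here, only one earlier instance of the change is available, and it sits on the core of compound 1 rather than on the core of compound 3, so the footing is thin. Still, the change on compound 3 is expected to give a small upward step because a 1.5-fold higher number from compound 1 to compound 2 (0.19 log units; within the scatter) was itself within the scatter. Compound 4 is therefore expected at about 27000 nM, with a likely range from 12000 nM to 60000 nM. This corresponds to an expected step of a 1.5-fold higher number from compound 3 to compound 4 (0.17 log units; within the scatter).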

Compound 4, half-maximal inhibitory concentration: 2330 nM
Beside the measured number, compound 4's estimate is 12-fold (1.06 log units) above it; the whole stated range lies above it.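

In this assay, 4-aminophenyl in place of 3,5-dimethoxyphenyl on the nitrogen did not carry over from one core to the other: on the bromo core it gave a 7.8-fold lower number from compound 3 to compound 4 (0.89 log units; beyond the scatter), and the two instances differ: the same change on two cores in this assay, a 1.5-fold higher number (0.19 log units; within the scatter) from compound 1 to compound 2 and a 7.8-fold lower number (0.89 log units; beyond the scatter) from compound 3 to compound 4, 12-fold (1.08 log units) apart, beyond the scatter of two such steps. Read the other way round the same four compounds, bromo in place of methoxy gave a 4.1-fold lower number from compound 2 to compound 4 (0.62 log units; beyond the scatter), which also fails to match its earlier instance: the same change on two cores in this assay, a 2.9-fold higher number (0.47 log units; beyond the scatter) from compound 1 to compound 3 and a 4.1-fold lower number (0.62 log units; beyond the scatter) from compound 2 to compound 4, 12-fold (1.08 log units) apart, beyond the scatter of two such steps. In these four compounds, therefore, the outcome of each change depends on the group present at the other place, so a step measured on one core is a poor guide to the same step on the other; this rests on a single pair of instances for each change, and it shows neither why the two groups interact nor whether the dependence extends to other compounds in the series.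

Open, as far as these compounds go, is whether the same dependence appears with a chloro group in place of the bromo or methoxy, or with a hydroxyl in place of the amine on the phenyl ring. Also open, from the compounds shown here alone, is whether it holds in any cell line other than the one used here.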